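Series notes: the amine swap from compound 3 to compound 4

This account rests on a few compounds, and the source may have more. Where it says the series, first, only, none or still open, it means among the compounds named here.

Of the compounds shown here, three have been measured in an assay on isolated protein for displacement of a labelled ligand from melanin-concentrating hormone receptor 1 (Homo sapiens); a lower number here means a stronger inhibitor, a higher number a weaker inhibitor. Compound 1 `O=C(CCc1ccc(C(F)(F)F)cc1)Nc1ccc2nc(N3CCC3)ccc2c1` gives 4 nM. Compound 2 `CN(c1ccc2cc(NC(=O)CCc3ccc(C(F)(F)F)cc3)ccc2n1)C1CCCC1` gives 2 nM; the step of a 2.0-fold lower number from compound 1 to compound 2 (0.30 log units; within the scatter) stays within the scatter, so the two cannot be ordered. Compound 3 `O=C(CCc1ccc(C(F)(F)F)cc1)Nc1ccc2nc(N3CCC(c4ccccc4)C3)ccc2c1` gives 25 nM, the highest number of the three, with a 6.3-fold higher number from compound 1 to compound 3 (0.80 log units; beyond the scatter) and a 13-fold higher number from compound 2 to compound 3 (1.10 log units; beyond the scatter) both beyond the scatter.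

Compound 4 `O=C(CCc1ccc(C(F)(F)F)cc1)Nc1ccc2nc(N3CCCCC3)ccc2c1` is not yet measured in this assay. The change from compound 3 is piperidin-1-yl in place of 3-phenylpyrrolidin-1-yl on an aromatic carbon. For the measured compounds named here, the only measured steps that touch this position are the two leading into compound 3: a 6.3-fold higher number from compound 1 to compound 3 (0.80 log units; beyond the scatter) and a 13-fold higher number from compound 2 to compound 3 (1.10 log units; beyond the scatter), both rises, where the 3-phenylpyrrolidin-1-yl group was the one feature set against the two smaller amines. Compound 4 carries piperidin-1-yl, a saturated amine without the phenyl, and so stands closer to the azetidin-1-yl of compound 1 and the cyclopentyl(methyl)amino of compound 2 than to compound 3. A fall in this assay is therefore expected for compound 4, with a step estimated as a 6.3-fold lower number from compound 3 to compound 4 (0.80 log units; beyond the scatter), taking it back near compound 1. Compound 4 is estimated at 4 nM, expected between 1.5 nM and 12 nM, since only three measured points inform the guess.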

Compound 4, half-maximal inhibitory concentration: 12 nM
For compound 4 the middle estimate is 3.0-fold (0.48 log units) below the measured one, and the stated range covers the measured number.
By their numbers in this assay, from the lowest: compounds 2 and 1 (each within the scatter of the next); then compound 4; then compound 3.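

The amine on the aromatic carbon next to the ring nitrogen now reads as more than a contrast between the phenyl-bearing group and everything else in this assay: removing the phenyl ring along with the change to piperidin-1-yl gives only a 2.1-fold lower number from compound 3 to compound 4 (0.32 log units; beyond the scatter), and compound 4 stays apart from both earlier amines, with a 3.0-fold higher number from compound 1 to compound 4 (0.48 log units; beyond the scatter) and a 6.0-fold higher number from compound 2 to compound 4 (0.78 log units; beyond the scatter). A saturated amine without a phenyl ring is therefore not enough on its own to reach the level of compound 1 and compound 2, and the order of the four compounds does not follow the heavy-atom count of the group, since the azetidin-1-yl of compound 1 and the cyclopentyl(methyl)amino of compound 2 both stand on the low side of piperidin-1-yl. No measurement at hand accounts for this order.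

Compound 3 and compound 4 differ in both ring size and the phenyl ring, so the share of each in their step stays unresolved. An unsubstituted pyrrolidin-1-yl or a 4-phenylpiperidin-1-yl at this position would separate the two, and a morpholin-4-yl would show whether a ring oxygen is accepted there.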